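Ethyl to tert-butyl on the pyridin-3-yl analogue

The source may report more compounds than this note shows. Statements on the series, on what has been measured and on what is new or still open speak of the compounds shown alone.

Among the measured compounds shown here, compound 3 `CCO/C(O)=C1\C(C)=NC(C)=C([N+](=O)[O-])C1c1cccnc1` gives 8840 nM in a functional assay (cardiac atrium) for agonist activity, with Cavia porcellus as the target (on this read-out lower numbers stand for an effect already at smaller amounts and higher numbers for an effect only at larger amounts of compound), the second highest of the three numbers so far. For the measured compounds named here, compound 1 `CC1=NC(C)=C([N+](=O)[O-])C(c2ccncc2)/C1=C(\O)OC(C)(C)C` gives 2820 nM and compound 2 `CC1=NC(C)=C([N+](=O)[O-])C(c2ccccn2)/C1=C(\O)OC(C)(C)C` gives 1810000 nM; the only step between single-point neighbours is a 640-fold higher number from compound 1 to compound 2 (2.81 log units; beyond the scatter), which concerns the ring on the saturated ring carbon, not the oxygen. Compound 4 `CC1=NC(C)=C([N+](=O)[O-])C(c2cccnc2)/C1=C(\O)OC(C)(C)C` differs from compound 3 by tert-butyl in place of ethyl on an oxygen on an unsaturated carbon. Going by the values given here, no measured pair isolates this change; compound 1 and compound 3 differ at two places at once, so their gap cannot be assigned. With nothing bearing on it, the expectation is a step near or within the scatter, written as a 1.5-fold lower number from compound 3 to compound 4 (0.17 log units; within the scatter). Compound 4 is thus estimated at 6000 nM, between 1500 nM and 25000 nM.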

Compound 4, half-maximal effective concentration: 14600 nM
For compound 4 the middle estimate is 2.4-fold (0.39 log units) below the measured one; the measured number falls inside the stated range.
By their numbers in this assay, from the lowest: compound 1; then compounds 3 and 4 (each within the scatter of the next); then compound 2.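

In this assay tert-butyl in place of ethyl on an oxygen on an unsaturated carbon gives a 1.7-fold higher number from compound 3 to compound 4 (0.22 log units; within the scatter) and so makes no readable difference on the pyridin-3-yl analogue. With tert-butyl held, the ring on the saturated ring carbon still separates the compounds: pyridin-3-yl in place of pyridin-2-yl gives a 120-fold lower number from compound 2 to compound 4 (2.09 log units; beyond the scatter) as a large step, while pyridin-3-yl in place of pyridin-4-yl gives a 5.2-fold higher number from compound 1 to compound 4 (0.71 log units; beyond the scatter) as a modest one. No supporting data explain these results.

On these data alone, whether ethyl and tert-butyl also read alike with pyridin-4-yl or pyridin-2-yl remains open. So does the reading of a longer chain or an amine on that oxygen.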